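Aryl sulfonamide series: extending the biaryl to naphthyl

The compounds below may be only part of what the source reports. "The series", "measured", "known", "first", "only" and "open" are said of these compounds alone.

Measured compounds in a functional assay on DLD-1 cells (Homo sapiens) for antiproliferative activity, read by CellTiter-Glo, with a stated time of 72 h; a higher number here means a weaker inhibitor, a lower number a stronger inhibitor:
- Compound 1, `CC1CCN(C2CCN(S(=O)(=O)c3cccc(Br)c3)CC2)CC1`: compound 1 gives 3.2 nM.
- Compound 2, `CC1CCN(C2CCN(S(=O)(=O)c3cccc(-c4ccc(Cl)cc4)c3)CC2)CC1`: compound 2 gives 15 nM.
- Compound 3, `COC(=O)c1ccc(S(=O)(=O)N2CCC(N3CCC(C)CC3)CC2)cc1`: compound 3 gives only a limit of the assay, > 5000 nM.

Compound 2 holds the highest of the two numbers in this assay; the nearest is compound 1, lower by a 4.7-fold higher number from compound 1 to compound 2 (0.67 log units; beyond the scatter). The third value is a limit and is not ranked with them (the limit of > 5000 nM in this assay, at which 1 of the 3 values shown sits).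

Compound 4, `CC1CCN(C2CCN(S(=O)(=O)c3cccc(-c4ccc5ccccc5c4)c3)CC2)CC1`, is not yet measured. It differs from compound 2 in one place: naphthalen-2-yl in place of 4-chlorophenyl on an aromatic carbon.

Among the measured compounds shown here, the only measured step that bears on this change is the one from compound 1 to compound 2, a 4.7-fold higher number from compound 1 to compound 2 (0.67 log units; beyond the scatter), in which the aryl substituent at the same aromatic carbon grew and the number rose. Compound 4 carries a still larger aryl group there, so the step from compound 2 to compound 4 is expected to be a 1.7-fold higher number from compound 2 to compound 4 (0.22 log units; within the scatter), in the same direction or flat within scatter. Compound 4 is expected to give 25 nM in this assay, with a range from 8 nM to 80 nM.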

Compound 4, half-maximal inhibitory concentration: 2 nM
Beside the measured number, compound 4's estimate is 13-fold (1.10 log units) above it; the measured number lies below the stated range.
By their numbers in this assay, from the lowest: compounds 4 and 1 (each within the scatter of the next); then compound 2. At a limit, above all of these: compound 3.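

In this assay, a larger aryl group at this aromatic carbon does not push the number only one way: a 4.7-fold higher number from compound 1 to compound 2 (0.67 log units; beyond the scatter), yet a 7.5-fold lower number from compound 2 to compound 4 (0.88 log units; beyond the scatter), so the number depends on which aryl group sits there and not simply on its heavy-atom count. The position also accepts naphthalen-2-yl in place of bromo with no separation between the two, a 1.6-fold lower number from compound 1 to compound 4 (0.20 log units; within the scatter). Nothing measured in this set gives a reason for the difference between 4-chlorophenyl and naphthalen-2-yl.

A phenyl group without the chlorine at this carbon would show whether the chlorine or the ring itself goes with the higher number of compound 2. Going by these compounds, whether an amine or a carboxylic acid on the naphthalen-2-yl group would keep the number low remains open.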